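From Dichlorobenzyl to Fluorobenzyl on a Shared Core

A few compounds are considered here, and "the series" means these few. Any claim that something is new, unique, unknown or untested is made for them only; others in the source may bear on it.

Of the compounds shown here, three built on one shared core have been tested in a functional assay on SK-MEL-5 cells (Homo sapiens) for inhibition, read by sulforhodamine B assay, with a stated time of 48 h; on this read-out lower numbers stand for stronger inhibition of growth and higher numbers for weaker inhibition of growth. Compound 1, `Nc1cc(N)c2nc(-c3ccccc3)c(NCc3ccc(Cl)c(Cl)c3)nc2c1`, gives 10700 nM. Compound 2, `CCOC(=O)[C@H](CCC(=O)O)NC(=O)c1ccc(Sc2nc3cc(N)cc(N)c3nc2-c2ccccc2)cc1`, gives 32400 nM, and compound 3, `CCOC(=O)[C@H](CCC(=O)O)NC(=O)c1ccc(Oc2nc3cc(N)cc(N)c3nc2-c2ccccc2)cc1`, gives 53700 nM. Compound 1 thus has the lowest number of the three, and its gaps to both compound 2 and compound 3 lie beyond the usual scatter of repeated measurements, so compound 1 stands as the strongest inhibitor of growth in this small set.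

Compound 4, `Nc1cc(N)c2nc(-c3ccccc3)c(NCc3ccc(F)cc3)nc2c1`, differs from compound 1 in one place only: 4-fluorophenyl in place of 3,4-dichlorophenyl on a saturated chain carbon bound to a nitrogen on an aromatic ring. Going by the values given here, no pair of measured compounds shows this same change, so its effect cannot be read off directly; compound 2 and compound 3 differ from compound 1 at another position and give no guidance here. Without a matching measured step, only a modest move toward a higher number is expected, possibly no larger than the scatter: a 1.9-fold higher number from compound 1 to compound 4 (0.27 log units; within the scatter). Compound 4 is expected to give 20000 nM, with a range from 7000 nM to 60000 nM.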

Compound 4, concentration for total growth inhibition: 3630 nM
Beside the measured number, compound 4's estimate is 5.5-fold (0.74 log units) above it; the whole stated range lies above it.
By their numbers in this assay, from the lowest: compound 4; then compound 1; then compounds 2 and 3 (each within the scatter of the next).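

In this assay, the group on the chain carbon bound to the nitrogen proves able to shift growth inhibition: 4-fluorophenyl in place of 3,4-dichlorophenyl gives a 2.9-fold lower number from compound 1 to compound 4 (0.47 log units; beyond the scatter), a step toward stronger inhibition. The earlier compounds shown here could not show this, as compounds 2 and 3 differ from compound 1 elsewhere, and the new step shows that the two chlorines are not required for this level of inhibition on the shared core. Nothing available explains why the swap lowers the number.

This single step removes two chlorines and adds a fluorine at once, so it cannot say which of those changes matters. A plain phenyl or a 4-chlorophenyl at this place would help separate them, and a longer chain would test how far the ring can sit from the nitrogen.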